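A few compounds are considered here, and "the series" means these few. Any claim that something is new, unique, unknown or untested is made for them only; others in the source may bear on it.

Measured compounds and their values in a functional assay on the whole organism with Rattus norvegicus as the target, at a dose of 100 mg/kg; on this read-out lower numbers stand for less inhibition and higher numbers for more inhibition at the one dose given (going by the name of the read-out):
compound 1, `O=c1ccc(-c2ccccc2)nn1CCCCNC(=S)NC1CCCCC1`: 18.1%
compound 2, `CC/N=C(/NC#N)NCCCn1nc(-c2ccccc2)ccc1=O`: 62.9%
compound 3, `N/C(S)=N/CCCCn1nc(-c2ccccc2)ccc1=O`: 72%

Compound 3 stands highest of the three numbers. Its nearest neighbour is compound 2, and the step of a number 9.1 percentage points higher from compound 2 to compound 3 (within the scatter) lies within the scatter, so the two cannot be ranked against each other. Within the data shown here, compound 1 lies far below compound 3, beyond the scatter; no single-point step is given for that pair, so only the two values can be set side by side.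

Compound 4, `C=CCNC(=S)NCCCCn1nc(-c2ccccc2)ccc1=O`, is not yet measured. Against compound 3 it shows (a group of 7 heavy atoms (4 carbon, 2 nitrogen, 1 sulfur; no ring) in place of a group of 4 heavy atoms (1 carbon, 2 nitrogen, 1 sulfur; no ring), on a saturated chain carbon, four bonds along the chain from an aromatic nitrogen). Among the measured compounds shown here, no measured step matches this change exactly. The step from compound 2 to compound 3 swapped a larger group for a smaller one and stayed within the scatter, which does not argue for a large move. Compound 1, however, carries a bulkier attachment of its own and gives 18.1%, while compound 3 gives 72%, which hints that adding to this part of the molecule can cost inhibition. A moderate downward step is therefore expected for compound 4, of about a number 24 percentage points lower from compound 3 to compound 4 (beyond the scatter). Compound 4 is estimated at 48%, with a likely range from 22% to 72%.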

Compound 4, a percentage reported as inhibition, in the whole organism at one dose (the size of the read-out at that dose, not a potency): 27.1%
The estimate for compound 4 lay 20.9 percentage points above the measured number; the range from low to high includes it.
By their numbers in this assay, from the lowest: compounds 1 and 4 (each within the scatter of the next); then compounds 2 and 3 (each within the scatter of the next).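

In this assay, the larger group on a saturated chain carbon, four bonds along the chain from an aromatic nitrogen, brings a clear loss: a number 44.9 percentage points lower from compound 3 to compound 4 (beyond the scatter). The same loss shows against the nitrile-bearing group of compound 2, with a number 35.8 percentage points lower from compound 2 to compound 4 (beyond the scatter), so both of the higher numbers are separated from compound 4. Allyl in place of cyclohexyl on the amide-type nitrogen gives a number 9 percentage points higher from compound 1 to compound 4 (within the scatter), so these two attachments cannot be ranked against each other, and neither restores the number lost.

Nothing measured here gives a reason for these steps. On these data alone, it remains open whether a single methyl on that nitrogen would keep the number of compound 3 at 72% or drop towards compound 4.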